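A few compounds are considered here, and "the series" means these few. Any claim that something is new, unique, unknown or untested is made for them only; others in the source may bear on it.

Of the compounds shown here, two sharing one core have been tested in a toxicity assay on the whole organism (strain albino) for activation, with Mus musculus as the target, with stated times of 30 min and 240 min; a higher number here means that more compound is needed for the effect, a lower number that less compound is needed. Going by the values given here, compound 2 `O=C(CN1CCN(c2cccc(Cl)c2)CC1)N(c1ccccc1)c1ccccc1` gives 48.4 mg/kg, the only plain number among the results. Compound 1 `Cc1ccc(N2CCN(CC(=O)N(c3ccccc3)c3ccccc3)CC2)cc1` reaches only a limit of the assay, > 40 mg/kg. Among the compounds with values here, the one measured step, a step that the limit leaves unreadable from compound 1 to compound 2, therefore cannot be sized, since one of its ends rests on (the limit of > 40 mg/kg in this assay, at which 1 of the 2 values shown sits).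

Compound 3 `O=C(CN1CCN(c2ccc(Cl)c(Cl)c2)CC1)N(c1ccccc1)c1ccccc1` differs from compound 2 by chloro in place of hydrogen on an aromatic carbon. Within the data shown here, no measured step shows what this change does; the unreadable step from compound 1 to compound 2 is the only neighbour, and it gives neither size nor direction. The expectation for this assay is thus a step of a 1.1-fold lower number from compound 2 to compound 3 (0.03 log units; within the scatter), no larger than the usual scatter. Compound 3 is accordingly expected to give about 45 mg/kg, within a range from 20 mg/kg to 100 mg/kg, in this assay.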

Compound 3, dose for half-maximal effect: 45 mg/kg
Estimate against measurement, compound 3: no gap at the digits printed; the measured number falls inside the stated range.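

In this assay, placing a chloro group on the aromatic carbon ortho to the existing chloro group and para to a large group, which turns 3-chlorophenyl into 3,4-dichlorophenyl, gives a 1.1-fold lower number from compound 2 to compound 3 (0.03 log units; within the scatter). Going by these compounds alone, this is the first step that can be read, and it shows that the doses for half-maximal effect of these two compounds cannot be told apart. The step that starts from compound 1 still cannot be read, as compound 1 gives only a limit of the assay: the limit of > 40 mg/kg in this assay, at which 1 of the 3 values shown sits.

From the compounds shown here alone, what a group other than chloro would do at this place, such as methoxy, an amine or a carboxylic acid, stays open. So does the effect of a chloro group here on a phenyl ring that carries no 3-chloro group.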